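This account rests on a few compounds, and the source may have more. Where it says the series, first, only, none or still open, it means among the compounds named here.

The measured compounds:
Compound 1 `Cc1ccc2c(NCc3ccc(NC(=O)C4CCN(Cc5cc(Cl)ccn5)CC4)cc3)nc(N(C)C)nc2c1` gives in a functional assay on SV5A8 cells (Homo sapiens) for cytotoxicity (on this read-out higher numbers stand for weaker inhibition and lower numbers for stronger inhibition), only the limit > 5400 nM.
Compound 2 `Cc1ccc2c(NCc3ccc(NC(=O)C4CCN(Cc5ccccc5F)CC4)cc3)nc(N(C)C)nc2c1` gives in this assay only the limit > 6670 nM.
Compound 3 `Cc1ccc2c(NCc3ccc(NC(=O)C4CCN(CC(C)C)CC4)cc3)nc(N(C)C)nc2c1` gives in this assay only the limit > 10500 nM.

Compound 3 thus stands at a limit, the point marked by the limit of > 10500 nM in this assay, at which 1 of the 3 values shown sits, and the two other values shown are limits as well. The steps a step that the two limits leave unreadable from compound 1 to compound 3, a step that the two limits leave unreadable from compound 2 to compound 3 and a step that the two limits leave unreadable from compound 1 to compound 2 all stay unreadable because each end sits at a limit such as the limit of > 5400 nM in this assay, at which 1 of the 3 values shown sits, or (the limit of > 6670 nM in this assay, at which 1 of the 3 values shown sits).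

Compound 4 `Cc1ccc2c(NCc3ccc(NC(=O)C4CCN(Cc5ccc(Cl)cc5)CC4)cc3)nc(N(C)C)nc2c1` differs from compound 3 as follows: 4-chlorophenyl in place of isopropyl on a saturated chain carbon bound to an amine nitrogen in a ring. Among the compounds with values here, the three measured steps bear on this change in one sense only: every exchange at this position so far has left the read-out at a limit, and none gives a readable size. The account therefore expects no step beyond the scatter in this assay and, most likely, another limit, so the estimated step that the limit leaves unreadable from compound 3 to compound 4 is a placeholder rather than a reading. Compound 4 is estimated at 15000 nM, within 5000 nM to 50000 nM.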

Compound 4, half-maximal inhibitory concentration: > 3180 nM
Compound 4: no number, only a limit; the forecaster's own chance of this, stated with the estimate: 85%; the middle value lies beyond the limit too.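

In this assay compound 4 gives only the limit > 3180 nM and no number. The steps to compound 4 from compound 1, compound 2 and compound 3 cannot be read. The compounds shown leave open whether any exchange at this position changes the read-out, and by how much.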